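A few compounds are considered here, and "the series" means these few. Any claim that something is new, unique, unknown or untested is made for them only; others in the source may bear on it.

In a functional assay on Jurkat cells (Homo sapiens) for inhibition, read by CCK-8 assay, with a stated time of 48 h (on this read-out lower numbers stand for stronger inhibition of growth and higher numbers for weaker inhibition of growth), compound 1 `CN1CCN(c2ccc(Nc3ncc(Cl)c(Nc4ccccc4)n3)nc2)CC1` gives only a limit, > 100000 nM. Going by the values given here, compound 2 `Cc1cccc(Nc2nc(Nc3ccc(N4CCN(C)CC4)cn3)ncc2Cl)c1` gives 15300 nM, the only exact number so far. With methyl in place of hydrogen on an aromatic carbon, the data show an at least 6.5-fold lower number from compound 1 to compound 2 (0.81 log units; beyond the scatter). From the compounds shown here alone, the true size of that step stays open, since it starts from the limit of > 100000 nM in this assay, at which 1 of the 2 values shown sits.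

Compound 3 `CC(C)c1cccc(Nc2nc(Nc3ccc(N4CCN(C)CC4)cn3)ncc2Cl)c1` has isopropyl in place of methyl on the same aromatic carbon, meta to a large group (isopropyl in place of methyl on an aromatic carbon). Among the compounds with values here, this enlarges the group whose arrival went with better growth inhibition, and that single step is the only guide. A further move in the same direction is therefore expected, but one step makes a weak trend, so the expected change is modest and uncertain: an estimated 2.6-fold lower number from compound 2 to compound 3 (0.41 log units; beyond the scatter). For compound 3 the expected value is 6000 nM, with an estimated range of 1500 nM to 24000 nM.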

Compound 3, concentration for 50% growth inhibition: 12300 nM
Estimate against measurement, compound 3: 2.1-fold (0.31 log units) below, within the range that was stated.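

In this assay, isopropyl in place of methyl on this aromatic carbon gives a 1.2-fold lower number from compound 2 to compound 3 (0.09 log units; within the scatter), so the further growth of the group brings no change that can be told apart from repeat-measurement noise. Isopropyl in place of hydrogen reads as an at least 8.1-fold lower number from compound 1 to compound 3 (0.91 log units; beyond the scatter), so what the data separate is hydrogen from either group, not methyl from isopropyl. From the compounds shown here alone, the true size of that step stays open because it starts from compound 1, which gives only a limit: the limit of > 100000 nM in this assay, at which 1 of the 3 values shown sits.

The compounds shown leave open whether a group of another kind on this same carbon, such as an amine, a methoxy group or a carboxylic acid, would stand apart from methyl and isopropyl. They also leave open whether a longer chain or a ring here would keep the level of compound 2 and compound 3.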